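Methoxy to hydroxy in a sulfonamide series

The source may report more compounds than this note shows. Statements on the series, on what has been measured and on what is new or still open speak of the compounds shown alone.

Three sulfonamides built on one shared core have been measured in a functional assay on DU-145 cells (Homo sapiens) for antiproliferative activity, read by MTT assay, with a stated time of 72 h; on this read-out lower numbers stand for stronger inhibition and higher numbers for weaker inhibition. Compound 1 `CN(c1cccc2ccccc12)S(=O)(=O)C1CC2OC1C(c1ccc(NC(=O)CCCCCCC(=O)O)cc1)=C2c1ccc(O)cc1` gives 70900 nM, compound 2 `CCN(c1cccc(C)c1)S(=O)(=O)C1CC2OC1C(c1ccc(NC(=O)CCCCCCC(=O)O)cc1)=C2c1ccc(O)cc1` gives 65600 nM, and compound 3 `CCN(c1ccc(OC)cc1)S(=O)(=O)C1CC2OC1C(c1ccc(NC(=O)CCCCCCC(=O)O)cc1)=C2c1ccc(O)cc1` gives 24400 nM, the lowest number of the three. The step of a 1.1-fold lower number from compound 1 to compound 2 (0.03 log units; within the scatter) stays within the scatter, whereas the steps of a 2.9-fold lower number from compound 1 to compound 3 (0.46 log units; beyond the scatter) and a 2.7-fold lower number from compound 2 to compound 3 (0.43 log units; beyond the scatter) are modest but go beyond it.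

The next compound is compound 4 `CCN(c1ccc(O)cc1)S(=O)(=O)C1CC2OC1C(c1ccc(NC(=O)CCCCCCC(=O)O)cc1)=C2c1ccc(O)cc1`, which differs from compound 3 by hydrogen in place of methyl on an oxygen on an aromatic ring, so that 4-methoxyphenyl becomes 4-hydroxyphenyl. Among the measured compounds shown here, no measured step makes this exchange, so the evidence is indirect. Among these compounds, the largest change at the sulfonamide nitrogen is the modest step of a 2.9-fold lower number from compound 1 to compound 3 (0.46 log units; beyond the scatter), and the smaller exchange now at hand is not expected to exceed it. Compound 3 also sits at the low end of the three, which gives a slight lean towards a higher number. The expected change is a 1.3-fold higher number from compound 3 to compound 4 (0.12 log units; within the scatter), which is not expected to go beyond the scatter. For compound 4 the estimated value is 32000 nM, with an expected range from 13000 nM to 75000 nM.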

Compound 4, half-maximal inhibitory concentration: > 100000 nM
Compound 4 ended at the assay's limit (the forecaster's own chance of this, stated with the estimate: 8%); at least 3.1-fold (0.49 log units) between middle value and limit.
By their numbers in this assay, from the lowest: compound 3; then compounds 2 and 1 (each within the scatter of the next). At a limit, above all of these: compound 4.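

In this assay, among the compounds shown here, the exchange of methoxy for hydroxy gives an at least 4.0-fold higher number from compound 3 to compound 4 (0.61 log units; beyond the scatter), so the loss of a single methyl from the oxygen on an aromatic ring is enough to move the number beyond the scatter, where the earlier steps had exchanged whole groups on the sulfonamide nitrogen. The advantage of compound 3 therefore does not survive this change, and the comparisons with the other two compounds give an at least 1.5-fold higher number from compound 2 to compound 4 (0.18 log units; that floor lies within the scatter) and an at least 1.4-fold higher number from compound 1 to compound 4 (0.14 log units; that floor lies within the scatter), floors that lie within the scatter and so do not by themselves separate compound 4 from either. The reading for compound 4 is a limit of the assay and not a number: the limit of > 100000 nM in this assay, at which 1 of the 4 values shown sits.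

The compounds shown leave open how far compound 4 really lies from compound 3, and whether the same exchange would have a similar effect with the methyl(naphthalen-1-yl)amino group on the sulfonyl sulfur. They also leave open whether ethoxy, a longer ether chain, an amine or fluorine at this place would stay with compound 3 or fall with compound 4.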